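Moving the Nitro Group Along the Benzyl Ring

The compounds below may be only part of what the source reports. "The series", "measured", "known", "first", "only" and "open" are said of these compounds alone.

Among the measured compounds shown here, compound 2 `O=[N+]([O-])c1ccccc1CSc1nnc(-c2ccc3c(c2)OCCO3)n1-c1ccccc1` stands at the top of the two numbers in a functional assay on SW 1116 cells (Homo sapiens) for antiproliferative activity, read by MTT assay, with a stated time of 24 h (on this read-out lower numbers stand for stronger inhibition and higher numbers for weaker inhibition), giving 8300 nM; its only neighbour, compound 1 `c1ccc(CSc2nnc(-c3ccc4c(c3)OCCO4)n2-c2ccccc2)cc1`, gives 7930 nM, and the two sit within the scatter of each other. For the measured compounds named here, the single measured step, a 1.0-fold higher number from compound 1 to compound 2 (0.02 log units; within the scatter), places a nitro in place of hydrogen on an aromatic carbon. Compound 3 `O=[N+]([O-])c1cccc(CSc2nnc(-c3ccc4c(c3)OCCO4)n2-c2ccccc2)c1` has not yet been measured. Its difference from compound 2 is 3-nitrophenyl in place of 2-nitrophenyl on a saturated chain carbon bound to a sulfur; the same atoms are joined differently, reading 2-nitrobenzyl to 3-nitrobenzyl one bond further out. Going by the values given here, no measured step addresses a shift of the nitro, and the one related step, a 1.0-fold higher number from compound 1 to compound 2 (0.02 log units; within the scatter), lay within the scatter, so the expected step of no change at the digits printed from compound 2 to compound 3 (within the scatter) is none beyond the scatter. Compound 3 is therefore estimated to give 8300 nM in this assay, with a range from 4000 nM to 17000 nM.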

Compound 3, half-maximal inhibitory concentration: 7590 nM
The estimate for compound 3 lay 1.1-fold (0.04 log units) above the measured number, and the stated range covers the measured number.
By their numbers in this assay, from the lowest: compounds 3, 1 and 2 (each within the scatter of the next).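

Shifting the nitro along the benzyl ring (a 1.1-fold lower number from compound 2 to compound 3 (0.04 log units; within the scatter)) leaves 2-nitrobenzyl and 3-nitrobenzyl indistinguishable in this assay, so this change of position has no readable effect here. The second placement also fails to separate from the unsubstituted benzyl (a 1.0-fold lower number from compound 1 to compound 3 (0.02 log units; within the scatter)), which means that, on the 3-nitrophenyl as on the 2-nitrophenyl, nitro in place of hydrogen on an aromatic carbon gives no step beyond the scatter. No supporting measurement bears on why the three compounds coincide.

With every step inside the scatter, the compounds shown do not reveal whether this benzyl ring can influence the read-out at all. From the compounds shown here alone, whether an amine or a carboxylic acid on that ring would give a step beyond the scatter remains open.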